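Swapping a para substituent on the shared anilino core

The compounds below may be only part of what the source reports. "The series", "measured", "known", "first", "only" and "open" are said of these compounds alone.

The series shares the core of compound 1 `NC(=O)c1ccc(NC2=CC(=O)c3ncncc3C2=O)cc1` and varies a single group on the aniline ring. In a functional assay on MIA PaCa-2 cells (Homo sapiens) for cytotoxicity, read by MTT assay, with a stated time of 72 h (on this read-out higher numbers stand for weaker inhibition and lower numbers for stronger inhibition), compound 1 gives 8000 nM. Compound 2 `NS(=O)(=O)c1ccc(NC2=CC(=O)c3ncncc3C2=O)cc1` carries a sulfamoyl there; in this assay compound 2 reaches only the limit of > 10000 nM, a limit rather than a number. Compound 3 `O=C1C(Nc2ccc(CO)cc2)=CC(=O)c2ncncc21` carries a hydroxymethyl and in this assay compound 3 gives 3500 nM, the lowest number among the two compounds reported as numbers. The step of a 2.3-fold lower number from compound 1 to compound 3 (0.36 log units; beyond the scatter) is modest, and the step of an at least 2.8-fold lower number from compound 2 to compound 3 (0.45 log units; beyond the scatter) is at least modest. The latter step rests on a limit (the limit of > 10000 nM in this assay, at which 1 of the 3 values shown sits).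

Compound 4 `CCOC(=O)c1ccc(NC2=CC(=O)c3ncncc3C2=O)cc1` differs from compound 3 by one change: ethoxycarbonyl in place of hydroxymethyl on an aromatic carbon. Among the compounds with values here, no measured step bears directly on an ethoxycarbonyl, so the expectation for this assay rests only on the two modest steps above, which show that changes at this position move the number but not greatly. Compound 4 is therefore expected to sit near compound 3, with the estimated step of a 1.1-fold higher number from compound 3 to compound 4 (0.06 log units; within the scatter). For compound 4 the estimate in this assay is 4000 nM, within a range of 1500 nM to 12000 nM.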

Compound 4, half-maximal inhibitory concentration: 5500 nM
For compound 4 the middle estimate is 1.4-fold (0.14 log units) below the measured one, within the range that was stated.
By their numbers in this assay, from the lowest: compounds 3, 4 and 1 (each within the scatter of the next, the first and the last beyond it). At a limit, above all of these: compound 2.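

In this assay, ethoxycarbonyl, with 5 heavy atoms and 0 hydrogen-bond donors, takes the place of hydroxymethyl, with 2 heavy atoms and 1 hydrogen-bond donor, in a step that stays within the scatter (a 1.6-fold higher number from compound 3 to compound 4 (0.20 log units; within the scatter)), so at this position neither that donor nor the smaller size shows a clear mark on the number. Ethoxy in place of amino on the carbonyl carbon also stays within the scatter (a 1.5-fold lower number from compound 1 to compound 4 (0.16 log units; within the scatter)), which leaves compound 4 within the scatter of both compound 1 and compound 3, even though those two lie beyond the scatter of each other, and so gives it no rank of its own among them. Compound 2 stands at a limit rather than a number, and the floor of its step (an at least 1.8-fold lower number from compound 2 to compound 4 (0.25 log units; that floor lies within the scatter)) lies within the scatter, so that step separates nothing: the limit of > 10000 nM in this assay, at which 1 of the 4 values shown sits.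

The compounds shown leave open whether a carboxylic acid or an amine at this position would move the number beyond the scatter. They also leave open whether a longer alkyl ester would stay level with the ethoxycarbonyl of compound 4.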